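Two measured points, one fused-ring replacement to judge

The source may report more compounds than this note shows. Statements on the series, on what has been measured and on what is new or still open speak of the compounds shown alone.

Measured so far:
compound 1 `O=C1CCC(=O)N1Cc1cc2nccc(-c3cc(Cl)cc4c3O[C@@H](c3ocnc3CN3CCC3)C4)c2s1` — 13 nM
compound 2 `Cc1cc(Cl)cc(-c2ccnc3cc(CN4C(=O)C5C(C4=O)C5(C)C)sc23)c1C[C@@H]1CNCCO1` — 0.44 nM

In an assay on isolated protein for inhibition of ubiquitin carboxyl-terminal hydrolase 7 (Homo sapiens), read by fluorescence, with stated times of 30 min and 1 h (a higher number here means a weaker inhibitor, a lower number a stronger inhibitor), compound 1 gives the higher of the two numbers; compound 2 sits far lower, beyond the scatter, but the two share no single-point change, so only the two values themselves are known.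

Compound 3 `O=C1CCC(=O)N1Cc1cc2nccc(-c3cc(Cl)cc4c3O[C@@H](c3onc5c3CNCC5)C4)c2s1` differs from compound 1 in one place: a group of 9 heavy atoms (6 carbon, 2 nitrogen, 1 oxygen; one five-membered aromatic ring with 2 hetero atoms, one six-membered non-aromatic ring with 1 hetero atom) in place of a group of 10 heavy atoms (7 carbon, 2 nitrogen, 1 oxygen; one four-membered non-aromatic ring with 1 hetero atom, one five-membered aromatic ring with 2 hetero atoms), on a saturated ring carbon. Going by the values given here, no measured pair shows a change of this kind, so the step is expected to be small, in no clear direction, and the estimate for compound 3 is 10 nM (range 3 nM to 35 nM), which means an expected step of a 1.3-fold lower number from compound 1 to compound 3 (0.11 log units; within the scatter).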

Compound 3, half-maximal inhibitory concentration: 0.38 nM
For compound 3 the middle estimate is 26-fold (1.42 log units) above the measured one; the measured number lies below the stated range.
By their numbers in this assay, from the lowest: compounds 3 and 2 (each within the scatter of the next); then compound 1.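

On the saturated ring carbon next to the ring oxygen, a group with a five-membered aromatic ring and a six-membered non-aromatic ring replacing 4-((azetidin-1-yl)methyl)-1,3-oxazol-5-yl gives a 34-fold lower number from compound 1 to compound 3 (1.53 log units; beyond the scatter) in this assay. With the rest of the structure unchanged, this position clearly responds to the group it carries. No available data account for the gain, and it cannot be assigned to any single feature of the new group.

Still open, as far as these compounds go, is how a methyl group on the nitrogen of the six-membered ring would compare. From the compounds shown here alone, the effect of this group on the core of compound 2 is also open.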